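The source may report more compounds than this note shows. Statements on the series, on what has been measured and on what is new or still open speak of the compounds shown alone.

In an ADME assay for permeability, using PAMPA, at pH 4 (on this read-out lower numbers stand for lower permeability and higher numbers for higher permeability), compound 2 (`CCc1c(C)[nH]c2cc(OC)c(Cl)cc2c1=O`) gives 96.4 10^-6 cm/s and stands level with compound 3 (`CCc1c(C)[nH]c2cc(OC)c(Br)cc2c1=O`) at 81.9 10^-6 cm/s in this small set. Compound 1 (`Cc1[nH]c2ccccc2c(=O)c1/C=C/c1ccccc1`) gives a higher number at 222 10^-6 cm/s and lies clear of compound 2 beyond the scatter. For the measured compounds named here, the only measured step (a 1.2-fold lower number from compound 2 to compound 3 (0.07 log units; within the scatter)) is bromo in place of chloro on an aromatic carbon and stays within the scatter. Compound 4 (`CCCCC/C=C/c1c(C)[nH]c2cc(OC)c(Cl)cc2c1=O`) carries hept-1-en-1-yl in place of ethyl on an aromatic carbon. Going by the values given here, no measured step covers that change, and the halogen swap is a different one. Going by these compounds, no shift beyond the scatter is expected in this assay and the direction stays open, with an expected step (a 1.0-fold higher number from compound 2 to compound 4 (0.02 log units; within the scatter)) that is small. Compound 4 is estimated at 100 10^-6 cm/s within a wide range from 30 10^-6 cm/s to 250 10^-6 cm/s for now.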

Compound 4, apparent permeability: 280 10^-6 cm/s
Compound 4: middle estimate off by 2.8-fold (0.45 log units), on the low side; measured number outside the range, above it.
By their numbers in this assay, from the lowest: compounds 3 and 2 (each within the scatter of the next); then compounds 1 and 4 (each within the scatter of the next).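

In this assay, hept-1-en-1-yl in place of ethyl on the aromatic carbon ortho to a methyl group gives a 2.9-fold higher number from compound 2 to compound 4 (0.46 log units; beyond the scatter), a step beyond the scatter, whereas the halogen swap stayed within it. The number at this position therefore responds to a change of substituent, and the longer unsaturated chain is accepted without a drop. No evidence on the cause of this step is at hand. Going by these compounds, whether the step follows chain length or the double bond stays open; a saturated heptyl chain would separate the two. On these data alone, a chain ending in an amine or a carboxylic acid is also open.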